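Methoxy for fluoro on the thioether aryl ring

The source may hold more compounds than are shown below. What is called first, only, known or untested is meant among the compounds shown, and "the series" means these compounds.

Measured so far:
compound 1 `Nc1cc(N)c2nc(-c3ccccc3)c(Sc3ccc(F)cc3)nc2c1` — 85100 nM
compound 2 `COc1cc(CNc2nc3cc(N)cc(N)c3nc2-c2ccccc2)cc(OC)c1OC` — 49000 nM

The measure throughout is a functional assay on SF-268 cells (Homo sapiens) for inhibition, read by sulforhodamine B assay, with a stated time of 48 h; a higher number here means that more compound is tolerated, a lower number that less compound is tolerated. Compound 1 gives 85100 nM, the highest of the two numbers recorded. Going by the values given here, its only neighbour is compound 2, whose value of 49000 nM lies within the usual scatter of the assay, so the two compounds cannot be told apart on these numbers and neither can be called the more or less tolerated.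

Compound 3 `COc1ccc(Sc2nc3cc(N)cc(N)c3nc2-c2ccccc2)cc1` has not yet been measured. It departs from compound 1 in a single place: methoxy in place of fluoro on an aromatic carbon. Among the compounds with values here, no pair of measured compounds shows this change, so there is no step to lean on.

On that basis compound 3 is expected to sit close to compound 1, with a step of a 1.2-fold lower number from compound 1 to compound 3 (0.08 log units; within the scatter) that is expected to stay within the scatter and to have no clear direction. The estimate for compound 3 in this assay is 70000 nM, with a range from 30000 nM to 160000 nM.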

Compound 3, concentration lethal to 50% of the cells: < 100000 nM
Compound 3: only a limit was reported (the forecaster's own chance of this, stated with the estimate: 15%); the middle value is on the limit's open side.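

In this assay compound 3 is reported as < 100000 nM and this is a limit, not a number. Going by these compounds alone, no step from compound 1 to compound 3 can therefore be read: the limit of < 100000 nM in this assay, at which 1 of the 3 values shown sits. The compounds shown leave open whether 4-methoxyphenyl in place of 4-fluorophenyl on the sulfur shifts the value at all, and in which direction.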